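Swapping a vinyl for a phenyl on the ether chain

The source may report more compounds than this note shows. Statements on the series, on what has been measured and on what is new or still open speak of the compounds shown alone.

The compounds here were tested in a functional assay on BV-2 cells (Mus musculus) for inhibition, read by Griess assay, with a stated time of 24 h; on this read-out lower numbers stand for stronger inhibition and higher numbers for weaker inhibition. Compound 1 `C=CCOCc1cc(-c2cc(Br)ccc2OC)no1` gives 90400 nM in this assay. Compound 2 `COc1ccc(Br)cc1-c1cc(COCc2ccccc2)on1` is a close relative, and its result in this assay is a limit rather than a number: compound 2 gives > 200000 nM. The change behind this pair is phenyl in place of vinyl on a saturated chain carbon bound to an oxygen on a saturated carbon, and it brought an at least 2.2-fold higher number from compound 1 to compound 2 (0.34 log units; beyond the scatter), a step whose size is known only as far as the limit allows, since the limit of > 200000 nM in this assay, at which 1 of the 3 values shown sits, caps what the assay can report.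

Compound 3 `C=CCOCc1cc(-c2cc(CC=C)ccc2OC)no1` differs from compound 1 at another spot, namely (allyl in place of bromo on an aromatic carbon), and in this assay compound 3 gives 28700 nM, which is a 3.1-fold lower number from compound 1 to compound 3 (0.50 log units; beyond the scatter).

Compound 4 `C=CCc1ccc(OC)c(-c2cc(COCc3ccccc3)on2)c1` has not been measured yet. It is built from compound 3 by phenyl in place of vinyl on a saturated chain carbon bound to an oxygen on a saturated carbon, the same change that turned compound 1 into compound 2, at the same place. The two cores differ by allyl in place of bromo on an aromatic carbon. Because the earlier change brought an at least 2.2-fold higher number from compound 1 to compound 2 (0.34 log units; beyond the scatter), compound 4 is expected to show a weaker inhibition than compound 3, with an estimated step of a 3.0-fold higher number from compound 3 to compound 4 (0.47 log units; beyond the scatter). The estimate for compound 4 in this assay is therefore 85000 nM, expected to fall somewhere between 40000 nM and 200000 nM, with a real chance that only a limit is reported.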

Compound 4, half-maximal inhibitory concentration: > 200000 nM
Compound 4: only a limit was reported; the forecaster's own chance of this, stated with the estimate: 25%; middle value at least 2.3-fold (0.37 log units) from the limit.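

In this assay compound 4 gives > 200000 nM, which is a limit of the assay and not a true number. Phenyl in place of vinyl on the ether chain brings an at least 6.9-fold higher number from compound 3 to compound 4 (0.84 log units; beyond the scatter), so the change moves the read-out towards weaker inhibition on both the bromo core and the allyl core, and the two steps can be set side by side: the same change on two cores in this assay, an at least 2.2-fold higher number (0.34 log units; beyond the scatter) from compound 1 to compound 2 and an at least 6.9-fold higher number (0.84 log units; beyond the scatter) from compound 3 to compound 4; the limit leaves it open whether they differ. This shows that the direction of the change carried over between these two cores, but it does not show that its size stayed the same, and the step between compound 2 and compound 4 cannot be read either, as the results for these two compounds stop at the same ceiling: the limit of > 200000 nM in this assay, at which 2 of the 4 values shown sit.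

From the compounds shown here alone, it stays open whether a saturated chain such as propyl in place of the vinyl would hold on to the inhibition seen with compound 3, and whether a phenyl carrying an amine or a carboxylic acid would bring the read-out back to a measurable number. Going by these compounds alone, with only two cores in view, it is also open whether the same direction would hold on a core with a third group, such as a longer chain, in place of the bromo or allyl.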